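The source may hold more compounds than are shown below. What is called first, only, known or untested is meant among the compounds shown, and "the series" means these compounds.

Compound 1 `CN1C[C@@H]2CN(c3cccnc3)C[C@@H]2C1` — 26 nM
Compound 2 `Brc1ccc(N2C[C@H]3CNC[C@H]3C2)cn1` — 0.28 nM
Compound 3 `Cc1cccc(-c2ccc(N3C[C@H]4CN(C)C[C@H]4C3)cn2)c1` — 750 nM

In an assay on membranes from brain for displacement of a labelled ligand from Neuronal acetylcholine receptor; alpha4/beta2 (Rattus norvegicus) (a higher number here means a weaker inhibitor, a lower number a stronger inhibitor), compound 3 gives 750 nM, the highest number of the three measured compounds; compound 1 gives 26 nM and compound 2 gives 0.28 nM. Among the measured compounds shown here, the only measured step bearing on the present change is a 29-fold higher number from compound 1 to compound 3 (1.46 log units; beyond the scatter), in which a 3-methylphenyl group took the place of hydrogen on an aromatic carbon of the shared core. Compound 4 `CN1C[C@@H]2CN(c3ccc(-c4cccc(-c5ccccc5)c4)nc3)C[C@@H]2C1` has not yet been measured; it differs from compound 3 by phenyl in place of methyl on an aromatic carbon, the new group sitting meta to a large group. For the measured compounds named here, no measured pair shows phenyl replacing methyl, so the direction of this particular step is not settled by the data. Going by the values given here, the one related step, a 29-fold higher number from compound 1 to compound 3 (1.46 log units; beyond the scatter), shows that enlargement at this part of the core has so far raised the number, and a further enlargement is expected either to raise it again or to leave it within the scatter rather than to lower it. Compound 4 is therefore expected to give about 1500 nM, in a range of 400 nM to 6000 nM, which corresponds to an expected 2.0-fold higher number from compound 3 to compound 4 (0.30 log units; within the scatter).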

Compound 4, inhibition constant: 9800 nM
Beside the measured number, compound 4's estimate is 6.5-fold (0.82 log units) below it, and the stated range ends below it.
By their numbers in this assay, from the lowest: compound 2; then compound 1; then compound 3; then compound 4.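

In this assay, among the compounds shown here, the earlier step showed only that adding the 3-methylphenyl group to the core of compound 1 raised the number. The new step, a 13-fold higher number from compound 3 to compound 4 (1.12 log units; beyond the scatter), shows that the result also depends on what that added ring carries: phenyl in place of methyl, on an aromatic carbon meta to a large group, raises the number again, and the change lies beyond the scatter. Both single-place steps along this line therefore go the same way, and neither lowers the number.

The compounds shown do not tell whether a smaller change at this carbon, such as an ethyl group, a methoxy group or an amine in place of methyl, would also raise the number. What lies behind the rise also remains open, with no measurement here that speaks to it.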